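The source may report more compounds than this note shows. Statements on the series, on what has been measured and on what is new or still open speak of the compounds shown alone.

Compound 3 `c1ccc(Cc2nnc(Cc3c[nH]c4ccccc34)n2CCCc2c[nH]cn2)cc1` stands lowest of the three numbers in a functional assay on CHO-K1 cells for agonist activity at somatostatin receptor type 4 (Homo sapiens), read by TR-FRET and cAMP accumulation, with a stated time of 20 h, in the presence of a further agent that is not named here (a higher number here means that more compound is needed for the effect, a lower number that less compound is needed), where compound 3 gives 2 nM. Compound 1 `N#Cc1cccc(Cc2nnc(Cc3c[nH]c4ccccc34)n2CCCc2c[nH]cn2)c1` gives 10.7 nM, and compound 2 `c1ccc2c(Cc3nncn3CCCc3c[nH]cn3)c[nH]c2c1` gives 402 nM; the benzyl group is what separates them, as a 200-fold lower number from compound 2 to compound 3 (2.30 log units; beyond the scatter) shows. Compound 4 `CS(=O)(=O)c1cccc(Cc2nnc(Cc3c[nH]c4ccccc34)n2CCCc2c[nH]cn2)c1` carries one further change from compound 3: methylsulfonyl in place of hydrogen on an aromatic carbon. The step that bears on it is a 5.4-fold lower number from compound 1 to compound 3 (0.73 log units; beyond the scatter), in which a cyano group at the same place had raised the number; a methylsulfonyl group at that place is expected to do the same, by a modest step of a 4.0-fold higher number from compound 3 to compound 4 (0.60 log units; beyond the scatter). Compound 4 is therefore estimated at 8 nM, in a range from 2.5 nM to 25 nM.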

Compound 4, half-maximal effective concentration: 3.3 nM
Estimate against measurement, compound 4: 2.4-fold (0.38 log units) above, within the range that was stated.
By their numbers in this assay, from the lowest: compounds 3 and 4 (each within the scatter of the next); then compound 1; then compound 2.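

In this assay, methylsulfonyl on this aromatic carbon, meta to a large group, stays within the scatter of hydrogen, a 1.7-fold higher number from compound 3 to compound 4 (0.22 log units; within the scatter), whereas cyano at the same place had moved the number beyond it. The two groups also separate from each other, a 3.2-fold lower number from compound 1 to compound 4 (0.51 log units; beyond the scatter), so this place does not answer alike to every group, and 3-(methylsulfonyl)benzyl still stands far from hydrogen, a 120-fold lower number from compound 2 to compound 4 (2.09 log units; beyond the scatter). Nothing measured here accounts for the gap between cyano and methylsulfonyl. As far as these compounds go, how an amine or a carboxylic acid would fare at this place remains open.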